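Bromo to Fluoro on a Diaminotriazine Aryl Ring

This account rests on a few compounds, and the source may have more. Where it says the series, first, only, none or still open, it means among the compounds named here.

Measured compounds:
compound 1, `Nc1nc(N)nc(-c2cccc(F)c2)n1`, 70%;
compound 2, `Nc1nc(N)nc(-c2cccc(Br)c2)n1`, 96%;
compound 3, `Nc1nc(N)nc(-c2cc(Cl)ccc2Br)n1`, 81%.

All three were tested in a functional assay on the whole organism with Rattus norvegicus as the target, at a dose of 20 mg/kg by the intraperitoneal route; on this read-out lower numbers stand for less inhibition and higher numbers for more inhibition at the one dose given (going by the name of the read-out). Compound 2 gives 96%, and compound 1 gives 70%; the step of a number 26 percentage points lower from compound 2 to compound 1 (beyond the scatter) is the change (fluoro in place of bromo on an aromatic carbon). Compound 3 gives 81%; the difference between its core and that of compound 2 is not broken down here. Compound 4, `Nc1nc(N)nc(-c2cc(Cl)ccc2F)n1`, has not been measured. It differs from compound 3 by fluoro in place of bromo on an aromatic carbon, the same kind of change as from compound 2 to compound 1, though here the place is ortho to a group of 8 heavy atoms and para to a chloro group, rather than meta to a group of 8 heavy atoms. Because the earlier step was a number 26 percentage points lower from compound 2 to compound 1 (beyond the scatter), a step of roughly a number 26 percentage points lower from compound 3 to compound 4 (beyond the scatter) is expected in this assay. Compound 4 is estimated at 55%, between 35% and 75%.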

Compound 4, a percentage reported as inhibition, in the whole organism at one dose (the size of the read-out at that dose, not a potency): 89%
The estimate for compound 4 lay 34 percentage points below the measured number; the whole stated range lies below it.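

In this assay, fluoro in place of bromo on an aromatic carbon did not give one fixed step across the two cores: the same change on two cores in this assay, a number 26 percentage points lower (beyond the scatter) from compound 2 to compound 1 and a number 8 percentage points higher (within the scatter) from compound 3 to compound 4, 34 percentage points apart, beyond the scatter of two such steps

On the chloro-bearing core the exchange gives a number 8 percentage points higher from compound 3 to compound 4 (within the scatter), so no change in the read-out can be claimed there. For the compounds shown here, with only two pairs, this shows that the earlier step cannot simply be carried over, but not which difference between the cores matters, whether the place on the ring or the chloro group.

The compounds shown leave open how a methoxy group or a carboxylic acid in the bromo position would behave on either core. They also leave open whether other cores would follow the first step or the second.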